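Swapping butoxy for azido on a shared core

The compounds below may be only part of what the source reports. "The series", "measured", "known", "first", "only" and "open" are said of these compounds alone.

Values in a functional assay on HFF cells (Homo sapiens) for cytotoxicity; on this read-out lower numbers stand for stronger inhibition and higher numbers for weaker inhibition:
- compound 1 `CC(=O)OC1C(CI)OC(n2c(Cl)nc3cc(Cl)c(Cl)cc32)C1OC(C)=O`: 32000 nM
- compound 2 `CCCCOC[C@H]1OC(n2c(Cl)nc3cc(Cl)c(Cl)cc32)[C@H](O)[C@@H]1O`: 32000 nM

Compound 2 stands level with compound 1, within the scatter of repeated measurements. Compound 3 `[N-]=[N+]=NC[C@H]1OC(n2c(Cl)nc3cc(Cl)c(Cl)cc32)[C@H](O)[C@@H]1O` has not yet been measured. It departs from compound 2 by one change, azido in place of butoxy on a saturated chain carbon bound to a saturated ring carbon. Among the measured compounds shown here, no measured step shows what such a change does, so the only guide is compound 2 at 32000 nM. In this assay the estimated no change at the digits printed from compound 2 to compound 3 (within the scatter) is expected to stay within the scatter, with no direction favoured. For compound 3 the expected value is 32000 nM, with an estimated range of 10000 nM to 100000 nM.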

Compound 3, half-maximal inhibitory concentration: 32000 nM
Beside the measured number, compound 3's estimate shows no gap at the digits printed, within the range that was stated.
By their numbers in this assay, from the lowest: compounds 1, 2 and 3 (each within the scatter of the next).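

In this assay, azido in place of butoxy on a saturated chain carbon bound to a saturated ring carbon gives no change at the digits printed from compound 2 to compound 3 (within the scatter). This first measured step at this position shows that the read-out holds its level when the butoxymethyl group gives way to azidomethyl, so the butoxy chain and its oxygen are not required there for this value. No evidence at hand offers a reason for this result.

As far as these compounds go, whether an amine, a carboxylic acid or a longer chain at this position would shift the read-out remains open. So does whether any group placed there can move it at all.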